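Extending the amine on the acrylamide chain of a quinazoline series

A few compounds are considered here, and "the series" means these few. Any claim that something is new, unique, unknown or untested is made for them only; others in the source may bear on it.

Measured so far:
compound 1, `COc1cc2ncnc(N3CCc4ccccc43)c2cc1NC(=O)/C=C/CN(C)C`: 2190 nM
compound 2, `CCN(CC)C/C=C/C(=O)Nc1cc2c(N3CCc4ccccc43)ncnc2cc1OC`: 3690 nM
compound 3, `CN(C)C/C=C/C(=O)Nc1cc2c(N3CCc4ccccc43)ncnc2cc1O[C@@H]1CCOC1`: 1230 nM

All three were tested in a functional assay on PC-3 cells (Homo sapiens) for antiproliferative activity, read by MTT assay, with a stated time of 72 h; a higher number here means a weaker inhibitor, a lower number a stronger inhibitor. Compound 1 and compound 2 differ in one spot: diethylamino in place of dimethylamino on a saturated chain carbon bound to a double-bonded chain carbon. That change gave a 1.7-fold higher number from compound 1 to compound 2 (0.23 log units; within the scatter). Compound 1 and compound 3 differ elsewhere: oxolan-3-yl in place of methyl on an oxygen on an aromatic ring. That change gave a 1.8-fold lower number from compound 1 to compound 3 (0.25 log units; within the scatter). The gap between compound 3 and compound 2 is the only one among the three that lies beyond the usual scatter.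

Compound 4, `CCN(CC)C/C=C/C(=O)Nc1cc2c(N3CCc4ccccc43)ncnc2cc1O[C@@H]1CCOC1`, has not yet been measured. It differs from compound 3 in the same way that compound 2 differs from compound 1: diethylamino in place of dimethylamino on a saturated chain carbon bound to a double-bonded chain carbon. The place of the change is the same in both pairs, so the same change is made on a core that carries the larger ether group of compound 3 instead of the smaller one of compound 1.

Because the earlier step gave a 1.7-fold higher number from compound 1 to compound 2 (0.23 log units; within the scatter), the step from compound 3 to compound 4 is expected to be of similar size, that is a 1.7-fold higher number from compound 3 to compound 4 (0.23 log units; within the scatter), resting on one prior example only. Compound 4 is therefore estimated at 2100 nM in this assay, with a likely range from 900 nM to 4800 nM.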

Compound 4, half-maximal inhibitory concentration: 5780 nM
Estimate against measurement, compound 4: 2.8-fold (0.44 log units) below; measured number outside the range, above it.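

The swap of dimethylamino for diethylamino did not carry over at a fixed size: on the core with the oxolan-3-yl ether, in this assay, it gave a 4.7-fold higher number from compound 3 to compound 4 (0.67 log units; beyond the scatter), and this step differs from the one on the core with the methyl ether: the same change on two cores in this assay, a 1.7-fold higher number (0.23 log units; within the scatter) from compound 1 to compound 2 and a 4.7-fold higher number (0.67 log units; beyond the scatter) from compound 3 to compound 4, 2.8-fold (0.45 log units) apart, beyond the scatter of two such steps

The same pairs can be read the other way, with oxolan-3-yl replacing methyl on the diethylamino side, which gave a 1.6-fold higher number from compound 2 to compound 4 (0.19 log units; within the scatter), and this step also differs from its counterpart on the dimethylamino side: the same change on two cores in this assay, a 1.8-fold lower number (0.25 log units; within the scatter) from compound 1 to compound 3 and a 1.6-fold higher number (0.19 log units; within the scatter) from compound 2 to compound 4, 2.8-fold (0.45 log units) apart, beyond the scatter of two such steps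

Together these show that, in these four compounds, the two changes do not simply add up, so a step measured on one core is a poor guide to its size on the other, but they rest on a single set of four compounds and do not show why this happens or whether it holds elsewhere in the series.

The compounds shown leave open how a cyclic amine such as pyrrolidine or morpholine would behave in place of diethylamino. They also leave open whether a different ether on that oxygen, such as ethyl, would follow compound 3 or compound 1.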